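From compound 2 to compound 3 in one series

This account rests on a few compounds, and the source may have more. Where it says the series, first, only, none or still open, it means among the compounds named here.

- Compound 1 `O=C1NC(O)(CCn2cnc3cncc(Br)c32)C(OCc2ccccc2)=C1OCc1ccccc1` | > 100000 nM
- Compound 2 `O=C1NC(O)(CCn2cnc3ccnc(Cl)c32)C(OCc2ccccc2)=C1OCc1ccccc1` | > 100000 nM

Both entries come from a functional assay on SW-620 cells (Homo sapiens) for antiproliferative activity, read by MTT assay, with a stated time of 72 h (on this read-out higher numbers stand for weaker inhibition and lower numbers for stronger inhibition), and neither is a number. Compound 2 gives > 100000 nM as a limit of the assay, so its standing is known only as a limit. Compound 1 gives > 100000 nM and this too is a limit.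

Compound 3 `Nc1nc(F)c(Cl)c2c1ncn2CCC1(O)NC(=O)C(OCc2ccccc2)=C1OCc1ccccc1` differs from compound 2 by a group of 12 heavy atoms (6 carbon, 4 nitrogen, 1 fluorine, 1 chlorine; one five-membered aromatic ring with 2 hetero atoms, one six-membered aromatic ring with 1 hetero atom) in place of a group of 10 heavy atoms (6 carbon, 3 nitrogen, 1 chlorine; one five-membered aromatic ring with 2 hetero atoms, one six-membered aromatic ring with 1 hetero atom), on a saturated chain carbon, two bonds along the chain from a saturated ring carbon and the rest of the structure is shared. Within the data shown here, the one measured step that bears on this change is a step that the two limits leave unreadable from compound 1 to compound 2 and it offers no size to carry forward. The expectation in this assay is therefore no readable step in either direction because the limit of > 100000 nM in this assay, at which 2 of the 2 values shown sit, is all that the series has shown so far. A further reported limit is the likeliest result. The estimated step is a number no higher from compound 2 to compound 3 (the limit leaves the size open) and it remains only an expectation. For compound 3 the estimated value is 100000 nM with an expected range from 30000 nM to 200000 nM in this estimate.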

Compound 3, half-maximal inhibitory concentration: 59000 nM
Compound 3: middle estimate off by 1.7-fold (0.23 log units), on the high side; measured number inside the range.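

Among the compounds shown, a change at this place, on a saturated chain carbon, two bonds along the chain from a saturated ring carbon, now gives a reading that is a number rather than a limit: compound 3, with the group of 12 heavy atoms, is the first in this assay to do so. Against the two groups of 10 heavy atoms, the change gives an at least 1.6-fold lower number from compound 2 to compound 3 (0.22 log units; that floor lies within the scatter) and an at least 1.6-fold lower number from compound 1 to compound 3 (0.22 log units; that floor lies within the scatter). The true size of each step stays open, and neither can be called a gain beyond the scatter, because the comparison rests on a limit of the assay at both starting compounds: the limit of > 100000 nM in this assay, at which 2 of the 3 values shown sit.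

The step between compound 1 and compound 2 cannot be read, so the exchange of bromine and chlorine, together with the shift in their place, remains without a size. The compounds shown do not separate the contributions of the fluorine and the added nitrogen in the entering group, and they leave open how the reading would respond to a methoxy group in place of the chlorine or to a longer chain.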